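The source may report more compounds than this note shows. Statements on the series, on what has been measured and on what is new or still open speak of the compounds shown alone.

Measured in a functional assay on SW480 cells (Homo sapiens) for cytotoxicity, read by MTT assay, with a stated time of 4 days; a lower number here means a stronger inhibitor, a higher number a weaker inhibitor:
- compound 1 `C=C1C[C@]23C[C@@]1(O)CC[C@H]2c1ccc(O)c(C)c1[C@@H]3Cn1cc(-c2ccccn2)nn1`, a limit of the assay: > 20000 nM
- compound 2 `C=C1C[C@]23C[C@@]1(O)CC[C@H]2c1ccc(OS(=O)(=O)c2ccc(C)cc2)c(C)c1[C@@H]3Cn1cc(-c2ccc(F)cc2)nn1`, a limit of the assay: > 20000 nM
- compound 3 `C=C1C[C@]23C[C@@]1(O)CC[C@H]2c1cc(Br)c(O)c(C)c1[C@@H]3Cn1cc(-c2ccccn2)nn1`, a limit of the assay: > 20000 nM

Compound 3 stands at the limit, as do the other two values shown (the limit of > 20000 nM in this assay, at which 3 of the 3 values shown sit). Among the measured compounds shown here, no ranking among the three is possible, and the only single-point step, a step that the two limits leave unreadable from compound 1 to compound 3, is left unreadable by the two limits; whether bromo in place of hydrogen on the aromatic carbon changes anything cannot be told.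

The next step is 4-chlorophenyl in place of pyridin-2-yl on an aromatic carbon, giving compound 4 `C=C1C[C@]23C[C@@]1(O)CC[C@H]2c1cc(Br)c(O)c(C)c1[C@@H]3Cn1cc(-c2ccc(Cl)cc2)nn1`. Compound 2, which carries a 4-fluorophenyl on the triazole together with a different group on the phenol oxygen, is also only a limit, so the closest comparison for an aryl on the triazole offers no number either. For the measured compounds named here, no measured step bears directly on this change. With every value shown sitting at the limit, compound 4 is expected to remain there as well, the estimated step that the limit leaves unreadable from compound 3 to compound 4 being no readable change. The estimate for compound 4 in this assay is 30000 nM, within 10000 nM to 100000 nM.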

Compound 4, half-maximal inhibitory concentration: 18000 nM
Beside the measured number, compound 4's estimate is 1.7-fold (0.22 log units) above it; the measured number falls inside the stated range.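

Among the compounds shown here, compound 4 gives the first readable number of the series in this assay, at 18000 nM, so the ring carbon of the five-membered aromatic ring with 3 nitrogen can carry 4-chlorophenyl with a value inside the range of the assay. On these data alone, the step is an at least 1.1-fold lower number from compound 3 to compound 4 (0.04 log units; that floor lies within the scatter), so a real change from pyridin-2-yl to 4-chlorophenyl is not established, and any upper size stays unknown. The series as a whole remains thinly resolved, with only compound 4 off the limit: the limit of > 20000 nM in this assay, at which 3 of the 4 values shown sit.

Open, as far as these compounds go, is what the bromo on the shared core contributes alongside 4-chlorophenyl. Also open, from the compounds shown here alone, is whether an amine or a carboxylic acid in place of the chlorine on the phenyl ring would move the number at all.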